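The source may hold more compounds than are shown below. What is called first, only, known or untested is meant among the compounds shown, and "the series" means these compounds.

Measured compounds:
compound 1, `COc1cc(N2C[C@H]3CCNC[C@H]32)cnc1Br`, 200 nM
compound 2, `N#Cc1cc(N2C[C@@H]3CCNC[C@@H]32)cnc1Br`, 109 nM

Two compounds have numbers in a functional assay on HEK293 cells for agonist activity at Neuronal acetylcholine receptor; alpha4/beta2 (Homo sapiens), read by FLIPR; on this read-out lower numbers stand for an effect already at smaller amounts and higher numbers for an effect only at larger amounts of compound. Compound 2 gives 109 nM and compound 1 gives 200 nM; the gap between them is within the scatter, so the two cannot be told apart on these data. Compound 2 is the reference point for the next step.

Compound 3, `N#Cc1cc(N2C[C@H]3CCNC[C@H]32)cnc1Br`, is not yet measured. It differs from compound 2 as follows: the two compounds have the same atoms and bonds and differ only in configuration as drawn: 2 of 2 stereo elements differ (all stereocentres are inverted: mirror images); a stereocentre at a saturated ring carbon is drawn S in compound 2 and R in compound 3; a stereocentre at a saturated ring carbon is drawn R in compound 2 and S in compound 3. Among the measured compounds shown here, no pair of mirror images has been measured, so the size and direction of such a step are not known from anything here. For compounds acting at this target, inverting both ring stereocentres may leave the number unchanged or may shift it well beyond the scatter, most often toward higher numbers, but that cannot be read from the two measured compounds.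

The estimate for compound 3 in this assay is therefore centred near 300 nM, with a wide range from 40 nM to 3000 nM, which corresponds to an expected step of a 2.8-fold higher number from compound 2 to compound 3 (0.44 log units; beyond the scatter).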

Compound 3, half-maximal effective concentration: 172 nM
Compound 3: the middle estimate sits 1.7-fold (0.24 log units) above what was measured; low and high end bracket the measured number.
By their numbers in this assay, from the lowest: compounds 2, 3 and 1 (each within the scatter of the next).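

In this assay, the mirror-image pair gives the first direct read on inverting both ring stereocentres with the nitrile in place: the step is a 1.6-fold higher number from compound 2 to compound 3 (0.20 log units; within the scatter), so the two mirror images cannot be told apart here. At the configuration shared by compound 1 and compound 3, the comparison of the aromatic group is now also a change in one place, and cyano in place of methoxy gives a 1.2-fold lower number from compound 1 to compound 3 (0.07 log units; within the scatter), again with no readable difference. Compound 1 and compound 2 differed in both the aromatic group and the configuration, whereas the step between the mirror images can be assigned to configuration alone, because of one point: the fact that compounds 2 and 3 differ only in the configuration as drawn

Open is whether this tolerance of both changes extends to the mirror image of compound 1 or holds only for the pairs shown. Also open, as far as these compounds go, is how the number in this assay would respond at the same aromatic carbon to an amine, a carboxylic acid or a longer chain such as butoxy, in either configuration of the shared core.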